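The compounds below may be only part of what the source reports. "The series", "measured", "known", "first", "only" and "open" are said of these compounds alone.

Values in a functional assay on cells (leukaemia cell line, Homo sapiens) for inhibition, read by sulforhodamine B assay, with a stated time of 48 h; on this read-out lower numbers stand for stronger inhibition of growth and higher numbers for weaker inhibition of growth:
- Compound 1 `Cc1ccc(NS(=O)(=O)c2ccc(-c3cnc(C4CC4)o3)cc2)cc1C`: > 100000 nM (a limit of the assay, not a number)
- Compound 2 `O=S(=O)(Nc1ccc(F)cc1F)c1ccc(-c2cnc(C3CC3)o2)cc1`: 66100 nM
- Compound 3 `COc1cc(NS(=O)(=O)c2ccc(-c3cnc(C4CC4)o3)cc2)ccc1F`: 75700 nM

In this assay compound 3 gives 75700 nM. Its nearest neighbour is compound 2, and the gap, a 1.1-fold higher number from compound 2 to compound 3 (0.06 log units; within the scatter), does not allow the two to be ranked. Compound 1 gives > 100000 nM, and this is a limit, as the limit of > 100000 nM in this assay, at which 1 of the 3 values shown sits, records.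

The next compound, compound 4 `Cc1cc(F)cc(NS(=O)(=O)c2ccc(-c3cnc(C4CC4)o3)cc2)c1`, has 3-fluoro-5-methylphenyl in place of 4-fluoro-3-methoxyphenyl on a sulfonamide nitrogen. The rest of the molecule stays the same.

Every measured step bearing on this swap changes the group on that same nitrogen. Among the compounds with values here, the only step between two real numbers is a 1.1-fold higher number from compound 2 to compound 3 (0.06 log units; within the scatter), which is small. The other two start from the limit, so they fix only a floor: an at least 1.5-fold lower number from compound 1 to compound 2 (0.17 log units; that floor lies within the scatter) and an at least 1.3-fold lower number from compound 1 to compound 3 (0.12 log units; that floor lies within the scatter). Both floors lie within the scatter, so neither shows a real shift.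

With these steps as the guide, no shift beyond the scatter is expected in this assay, and the estimated change is a 1.0-fold lower number from compound 3 to compound 4 (0.00 log units; within the scatter). The estimate for compound 4 is 75000 nM, with an expected range from 40000 nM to 100000 nM.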

Compound 4, concentration for total growth inhibition: 7250 nM
Compound 4: the middle estimate sits 10-fold (1.01 log units) above what was measured; the whole stated range lies above it.
By their numbers in this assay, from the lowest: compound 4; then compounds 2 and 3 (each within the scatter of the next). At a limit, above all of these: compound 1.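

At this place on the sulfonamide nitrogen, the earlier swaps gave no shift that could be read, so the group there might have seemed to matter little in this assay; compound 4 shows that it can matter a great deal, with a 10-fold lower number from compound 3 to compound 4 (1.02 log units; beyond the scatter) and a 9.1-fold lower number from compound 2 to compound 4 (0.96 log units; beyond the scatter). The comparison with the third earlier compound points the same way, with an at least 13-fold lower number from compound 1 to compound 4 (1.13 log units; beyond the scatter), a floor that already lies beyond the scatter, so 3-fluoro-5-methylphenyl gives the lowest number of the four, and the change depends on more than simply having a substituted phenyl ring on this nitrogen. Compound 1 stands at a limit, not a number: the limit of > 100000 nM in this assay, at which 1 of the 4 values shown sits.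

The compounds shown cannot separate the share of the fluoro group, the methyl group and their arrangement on the ring, as compound 4 alone carries this pattern, and nothing here says why it gives the lower number. Going by these compounds, how a phenyl ring bearing an amine, a carboxylic acid or a longer chain would behave at this place in this assay also remains open.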